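The source may report more compounds than this note shows. Statements on the series, on what has been measured and on what is new or still open speak of the compounds shown alone.

Measured compounds:
compound 1, structure `COc1ccc(C(=O)/C=C/c2ccc(Br)cc2)c2c1C=CC(C)(C)O2`, result > 10000 nM (a limit)
compound 2, structure `COc1ccc(C(=O)/C=C/c2ccc3ccccc3n2)c2c1C=CC(C)(C)O2`, result 2250 nM

In a functional assay on SW-620 cells (Homo sapiens) for antiproliferative activity, read by MTT assay, with a stated time of 24 h (a higher number here means a weaker inhibitor, a lower number a stronger inhibitor), compound 1 is reported only as a limit of the assay, > 10000 nM, not as a number. Compound 1 therefore stands at the limit of > 10000 nM in this assay, at which 1 of the 2 values shown sits, and how far beyond that point it lies cannot be read from the data. Going by the values given here, compound 2 in this assay gives 2250 nM; no one-place step connects compound 1 and compound 2, so only the two values as such are set side by side, and they show compound 2 with a number where compound 1 has none.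

Compound 3, structure `COc1ccc(C(=O)/C=C/c2ccc([N+](=O)[O-])cc2)c2c1C=CC(C)(C)O2`, differs from compound 1 by nitro in place of bromo on an aromatic carbon. Among the compounds with values here, no measured pair in the set carries this change, so nothing here fixes its direction or size. Because compound 1 sits at the limit of > 10000 nM in this assay, at which 1 of the 2 values shown sits, any move toward a weaker inhibitor would again be hidden by the limit, and only a move toward a stronger one would become visible. The step from compound 1 to compound 3 is expected to be an at least 1.1-fold lower number from compound 1 to compound 3 (0.04 log units; that floor lies within the scatter), that is, not clearly beyond the scatter in either direction. Compound 3 is estimated at 9000 nM, within 2500 nM to 40000 nM, with a real chance that this assay again reports only a limit.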

Compound 3, half-maximal inhibitory concentration: 3520 nM
The estimate for compound 3 lay 2.6-fold (0.41 log units) above the measured number; low and high end bracket the measured number.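

In this assay, going by these compounds alone, the change from 4-bromophenyl to 4-nitrophenyl gives an at least 2.8-fold lower number from compound 1 to compound 3 (0.45 log units; beyond the scatter) and is the first one-place step that can be read. It shows that this place on the aromatic ring, para to a large group, is not indifferent to the group it carries: with the rest of the structure unchanged, replacing bromo with nitro moves the result clearly beyond the scatter. The printed step is only a floor, and its true size stays unknown, since compound 1 is reported as a limit and not as a number: the limit of > 10000 nM in this assay, at which 1 of the 3 values shown sits.

This single pair does not establish a trend, and it cannot separate an effect specific to nitro from a more general gain on losing bromo at this place. As far as these compounds go, an amine, a nitrile or a carboxylic acid on the same aromatic carbon would test whether the result follows the nature of the entering group, and whether the same change holds on other parts of the core also remains open.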